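Cytotoxicity of Benzoxazole Sulfonamides: From Methoxy to Ethyl

A few compounds are considered here, and "the series" means these few. Any claim that something is new, unique, unknown or untested is made for them only; others in the source may bear on it.

Measured compounds:
- compound 1, `O=S(=O)(Nc1ccc2oc(-c3ccccc3)nc2c1)c1cccc(C(F)(F)F)c1`, > 100000 nM in an ADME assay on HEK293 cells (Homo sapiens) for cytotoxicity, read by resazurin assay, with a stated time of 48 h; a lower number here means that less compound is tolerated, a higher number that more compound is tolerated.
- compound 2, `C=Cc1ccc(S(=O)(=O)Nc2ccc(-c3nc4ccccc4o3)cc2)cc1`, > 100000 nM.
- compound 3, `COc1cccc(S(=O)(=O)Nc2ccc3oc(-c4ccccc4)nc3c2)c1`, 63000 nM.

For compound 1 the result in this assay is a limit, not a number. For compound 2 the result is also a limit. Compound 3 is the only one of the three that gives an actual number, and that number is 63000 nM. Two of the three results sit at the limit, as the limit of > 100000 nM in this assay, at which 2 of the 3 values shown sit, states. Going by the values given here, the one step measured between neighbours is an at least 1.5-fold lower number from compound 1 to compound 3 (0.20 log units; that floor lies within the scatter), which starts from a limit and therefore only sets a floor on the change.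

Compound 4 is `CCc1ccc(S(=O)(=O)Nc2ccc3oc(-c4ccccc4)nc3c2)cc1`. It differs from compound 3 by 4-ethylphenyl in place of 3-methoxyphenyl on a sulfonyl sulfur. Among the compounds with values here, no measured step covers this change: the one step known swaps groups on an aromatic carbon, not on the sulfonyl sulfur, so it bears on compound 4 only indirectly, by showing that such swaps here move the number little if at all. The expectation is therefore a step of a 1.1-fold higher number from compound 3 to compound 4 (0.05 log units; within the scatter), that is, no change beyond the scatter. Compound 4 is estimated at 70000 nM, with a range from 30000 nM to 150000 nM.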

Compound 4, half-maximal cytotoxic concentration: 81000 nM
Estimate against measurement, compound 4: 1.2-fold (0.06 log units) below; the measured number falls inside the stated range.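

Replacing 3-methoxyphenyl with 4-ethylphenyl on a sulfonyl sulfur gives, in this assay, a 1.3-fold higher number from compound 3 to compound 4 (0.11 log units; within the scatter). This is the first step among these compounds with an actual number at both ends, so its size can be read directly rather than only as a floor. Both groups have the same heavy-atom count and a six-membered aromatic ring of carbon only, but the entering group lacks the oxygen and the hydrogen-bond acceptor of the group it replaces, and in this one pair that difference comes with no change beyond the scatter.

On these data alone, whether a different kind of group on the sulfonyl sulfur, such as a phenyl ring bearing an amine, a carboxylic acid or a longer chain, would move the number beyond the scatter remains open. The results for compound 1 and compound 2 are limits and not numbers, so how far either lies from compound 4 cannot be read: the limit of > 100000 nM in this assay, at which 2 of the 4 values shown sit.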